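Swapping dimethylamino for piperazin-1-yl on compound 2

The source may hold more compounds than are shown below. What is called first, only, known or untested is meant among the compounds shown, and "the series" means these compounds.

In an ADME assay on cells (Homo sapiens) for cytotoxicity, read by sulforhodamine B assay, with a stated time of 48 h (on this read-out lower numbers stand for an effect already at smaller amounts and higher numbers for an effect only at larger amounts of compound), compound 2 `CN(C)c1ccc(/C=C2/SC(N(c3ccccc3)c3ccccc3)=NC2=O)cc1` reads > 100000 nM, which is a limit of the assay and not a number. Compound 3 `O=C1N=C(N(c2ccccc2)c2ccccc2)S/C1=C/c1ccc(N2CCNCC2)cc1` is the same as compound 2 except for one change: piperazin-1-yl in place of dimethylamino on an aromatic carbon, para to a large group (piperazin-1-yl in place of dimethylamino on an aromatic carbon). Within the data shown here, no measured pair of compounds differs in one place only, so no direct guide to this change exists. The nearest reference is compound 1 `CN1CCN(c2ccc(/C=C3/SC(Nc4ccccc4)=NC3=O)cc2)CC1`, which gives a true number, 6400 nM, in this assay. On the strength of that one value, a sizeable move towards lower numbers is expected, although a reading that stays at the limit remains possible. The expected change is an at least 4.0-fold lower number from compound 2 to compound 3 (0.60 log units; beyond the scatter). Compound 3 is estimated at 25000 nM, with an expected range of 5000 nM to 100000 nM.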

Compound 3, half-maximal effective concentration: > 100000 nM
Compound 3: a limit, no number; the forecaster's own chance of this, stated with the estimate: 30%; at least 4.0-fold (0.60 log units) between middle value and limit.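

Among these compounds, compound 2 and compound 3 both rest at a limit of the assay and not at a number, so no step between them can be read: the limit of > 100000 nM in this assay, at which 2 of the 3 values shown sit.

The compounds shown leave open what piperazin-1-yl in place of dimethylamino does to the value, as no pair differing only in that place gives two true numbers.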